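The source may hold more compounds than are shown below. What is called first, only, known or untested is meant among the compounds shown, and "the series" means these compounds.

Measured compounds:
compound 1 `Nc1scc(CN2CCN(c3ccc(Cl)c(C(F)(F)F)c3)CC2)c1C(=O)c1ccc(Cl)cc1`: -12%
compound 2 `Nc1scc(CN2CCN(c3cccc(F)c3)CC2)c1C(=O)c1cccc(C(F)(F)F)c1`: -12%

In a functional assay on CHO cells with adenosine receptor A1 (Homo sapiens) as the target, read by cAMP accumulation and immunoassay, with a stated time of 6 min, tested at 0.1 uM (a lower number here means a stronger effect, a higher number a weaker effect of the compound at the concentration tested), compound 1 gives -12%. In this assay compound 2 gives -12%, so compound 1 stands level with compound 2, the two values lying within the scatter of each other. Compound 3 `Nc1scc(CN2CCN(c3ccc(F)cc3F)CC2)c1C(=O)c1ccc(Cl)cc1` has not yet been measured in this assay. It differs from compound 1 in one place: 2,4-difluorophenyl in place of 4-chloro-3-(trifluoromethyl)phenyl on an amine nitrogen in a ring. Among the measured compounds shown here, no measured pair shows what such an exchange does, so the outlook rests only on the two values at hand, which sit together. The step of a number 2 percentage points higher from compound 1 to compound 3 (within the scatter) is expected to be none beyond the scatter. For compound 3 the estimate is -10%, with a range from -25% to 5%.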

Compound 3, a percentage reported as activity, at one concentration (the size of the read-out at that concentration, not a potency): -17%
For compound 3 the middle estimate is 7 percentage points above the measured one, and the stated range covers the measured number.
By their numbers in this assay, from the lowest: compounds 3, 1 and 2 (each within the scatter of the next).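

In this assay, among the compounds shown here, putting 2,4-difluorophenyl in place of 4-chloro-3-(trifluoromethyl)phenyl on an amine nitrogen in a ring gives a number 5 percentage points lower from compound 1 to compound 3 (within the scatter) and offers the first direct look at this position. Here, the smaller group with 8 heavy atoms cannot be told apart from the group it replaces at this single concentration. No measurement available here offers an explanation for this result. Still open, going by these compounds, is whether a pyridine ring or a benzyl group at this place would give a clearly different number. Also open, on these data alone, is whether these two groups would separate at other concentrations.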